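This account rests on a few compounds, and the source may have more. Where it says the series, first, only, none or still open, it means among the compounds named here.

Within the data shown here, compound 3 `CS(=O)(=O)c1cc(C(=O)N=C(N)N)ccc1C(F)(F)F` is one of three compounds so far measured in a functional assay for inhibition of sodium/hydrogen exchanger (Oryctolagus cuniculus); a lower number here means a stronger inhibitor, a higher number a weaker inhibitor. In this assay compound 3 gives 140 nM, the highest number of the three. Compound 2 `Cc1cc(C(F)(F)F)c(S(C)(=O)=O)cc1C(=O)N=C(N)N` gives 37 nM in this assay, and compound 1 `Cc1cc(Nc2ccccc2)c(S(C)(=O)=O)cc1C(=O)N=C(N)N` gives 21 nM in this assay. Among the measured compounds shown here, the only single-place step that reaches compound 3 is a 3.8-fold higher number from compound 2 to compound 3 (0.58 log units; beyond the scatter). Compound 4 `CS(=O)(=O)c1cc(C(=O)N=C(N)N)ccc1Oc1cncc(Cl)c1` has not yet been measured. It differs from compound 3 in one place: (5-chloropyridin-3-yl)oxy in place of trifluoromethyl on an aromatic carbon. The measured step that bears most on this change is a 1.8-fold higher number from compound 1 to compound 2 (0.25 log units; within the scatter), where an anilino group and a trifluoromethyl group at the same place on the core of compound 1 and compound 2 gave numbers within the scatter of each other. Compound 4 makes an exchange of the same kind in the opposite direction, putting an aromatic ring back in place of trifluoromethyl, but the entering (5-chloropyridin-3-yl)oxy group is not the anilino group, and nothing measured here speaks to it directly. The step in this assay is therefore expected to be small, at most a modest lowering of the number: a 1.4-fold lower number from compound 3 to compound 4 (0.15 log units; within the scatter). Compound 4 is estimated at 100 nM in this assay, with a likely range from 35 nM to 300 nM.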

Compound 4, half-maximal inhibitory concentration: 75 nM
The estimate for compound 4 lay 1.3-fold (0.12 log units) above the measured number; the measured number falls inside the stated range.
By their numbers in this assay, from the lowest: compounds 1 and 2 (each within the scatter of the next); then compounds 4 and 3 (each within the scatter of the next).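

At this place, ortho to a methylsulfonyl group, putting (5-chloropyridin-3-yl)oxy in place of trifluoromethyl gives a 1.9-fold lower number from compound 3 to compound 4 (0.27 log units; within the scatter) in this assay and so brings no clear change, even though the entering group has 8 heavy atoms and an aromatic ring while the leaving group has 4 heavy atoms and no ring. The earlier exchange at this place, a 1.8-fold higher number from compound 1 to compound 2 (0.25 log units; within the scatter) on a core carrying an extra methyl group, also stayed within the scatter, and the new step extends that observation to a core without the methyl group and to a different ring-bearing group. Nothing measured here explains why such different groups give numbers this close.

The compounds shown do not reveal whether the chlorine or the ring nitrogen matters, which a plain phenoxy group at this place could help to test, or whether a small amine or a carboxylic acid would fit as readily as these groups. They also leave open whether adding a methyl group to the core of compound 4 would lower the number, as the step between the two trifluoromethyl compounds might suggest.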